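A few compounds are considered here, and "the series" means these few. Any claim that something is new, unique, unknown or untested is made for them only; others in the source may bear on it.

Of the compounds shown here, three built on one shared core have been tested in a functional assay on SMMC-7721 cells (Homo sapiens) for cytotoxicity, read by MTT assay, with a stated time of 4 days; a lower number here means a stronger inhibitor, a higher number a weaker inhibitor. Compound 1 `C=C1C[C@]23C[C@@]1(O)CC[C@H]2c1ccc(OS(=O)(=O)c2ccc(C)cc2)c(C)c1[C@@H]3Cn1cc(-c2ccc(C)cc2)nn1` gives only a limit there, > 20000 nM. Compound 2 `C=C1C[C@]23C[C@@]1(O)CC[C@H]2c1ccc(OS(=O)(=O)c2ccc(C)cc2)c(C)c1[C@@H]3Cn1cc(-c2ccc(F)cc2)nn1` likewise gives only a limit in this assay, > 20000 nM. Compound 3 `C=C1C[C@]23C[C@@]1(O)CC[C@H]2c1ccc(O)c(C)c1[C@@H]3Cn1cc(-c2ccc(F)cc2)nn1` also gives only a limit in this assay, > 20000 nM. The step that the two limits leave unreadable from compound 1 to compound 2 cannot be read, and the same holds for a step that the two limits leave unreadable from compound 2 to compound 3 because of the limit of > 20000 nM in this assay, at which 3 of the 3 values shown sit. Compound 2 therefore stands at the edge of what this assay can report, side by side with the other two compounds rather than above or below them.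

Compound 4 `C=C1C[C@]23C[C@@]1(O)CC[C@H]2c1ccc(OS(=O)(=O)c2ccc(C)cc2)c(C)c1[C@@H]3Cn1cc(-c2ccccn2)nn1` has not yet been measured. It differs from compound 2 by pyridin-2-yl in place of 4-fluorophenyl on an aromatic carbon. Neither measured step gives a readable size that could guide this change, since both a step that the two limits leave unreadable from compound 1 to compound 2 and a step that the two limits leave unreadable from compound 2 to compound 3 are hidden by the limit. What the numbers do show is that swapping the group on the triazole, or removing the sulfonyl group, left every compound at the same limit. The step expected here is a number no higher from compound 2 to compound 4 (the limit leaves the size open), which is to say none beyond the scatter, with the result most likely again a limit. Compound 4 is accordingly estimated at 20000 nM, with a range from 6000 nM to 80000 nM.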

Compound 4, half-maximal inhibitory concentration: > 20000 nM
Compound 4: no number, only a limit (the forecaster's own chance of this, stated with the estimate: 80%); the middle value sits exactly at the limit.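

Compound 4 gives only a limit in this assay, > 20000 nM. Its steps from compound 1 and compound 2 therefore cannot be read, because all the compounds share one limit: the limit of > 20000 nM in this assay, at which 4 of the 4 values shown sit.

The compounds shown leave open how these compounds truly compare in this test, and which change to the shared core, if any, would give a measurable value.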